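A few compounds are considered here, and "the series" means these few. Any claim that something is new, unique, unknown or untested is made for them only; others in the source may bear on it.

Compound 1, `CCOC(=O)c1cnc(SC)nc1NN1C(=O)C=C(C)C1=O`: 200 nM
Compound 2, `CCOC(=O)c1cnc(-c2ccc(F)cc2)nc1NN1C(=O)C=C(C)C1=O`: 700 nM
Compound 3, `CCOC(=O)c1cnc(-c2ccc(C(F)(F)F)cc2)nc1NN1C(=O)C=C(C)C1=O`: 400 nM

In a functional assay on Jurkat cells for inhibition of nuclear factor NF-kappa-B complex (Homo sapiens) (on this read-out higher numbers stand for weaker inhibition and lower numbers for stronger inhibition), compound 3 stands among three close numbers: the step of a 2.0-fold higher number from compound 1 to compound 3 (0.30 log units; within the scatter) and the step of a 1.8-fold lower number from compound 2 to compound 3 (0.24 log units; within the scatter) both stay within the scatter, so none of the three can be called clearly stronger or weaker.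

Compound 4, `CCOC(=O)c1cnc(-c2ccc(C)s2)nc1NN1C(=O)C=C(C)C1=O`, differs from compound 3 by 5-methylthiophen-2-yl in place of 4-(trifluoromethyl)phenyl on an aromatic carbon. Within the data shown here, two measured steps touch the same place on the shared core: replacing methylsulfanyl by an aryl ring gave a 2.0-fold higher number from compound 1 to compound 3 (0.30 log units; within the scatter), and swapping the group on that aryl ring gave a 1.8-fold lower number from compound 2 to compound 3 (0.24 log units; within the scatter). Neither moved the number beyond the scatter, so for compound 4 the step of a 1.1-fold higher number from compound 3 to compound 4 (0.05 log units; within the scatter) is expected to stay within the scatter as well. Compound 4 is therefore estimated at 450 nM, in the range 200 nM to 1200 nM.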

Compound 4, half-maximal inhibitory concentration: 200 nM
Estimate against measurement, compound 4: 2.3-fold (0.35 log units) above; low and high end bracket the measured number.
By their numbers in this assay, from the lowest: compounds 1, 4, 3 and 2 (each within the scatter of the next, the first and the last beyond it).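

In this assay, 5-methylthiophen-2-yl on the shared core gives no change at the digits printed from compound 1 to compound 4 (within the scatter) and also a 2.0-fold lower number from compound 3 to compound 4 (0.30 log units; within the scatter) so an aromatic ring at this position can match methylsulfanyl. Compared with 4-fluorophenyl, the same group gives a 3.5-fold lower number from compound 2 to compound 4 (0.54 log units; beyond the scatter) and this is the first swap of one ring for another here to pass the scatter. Nothing measured here explains that gap.

Still open is whether the methyl on the thiophene ring matters, since thiophen-2-yl without it is not among these compounds. On these data alone, how an amine or a longer alkyl chain would behave at this position also remains unknown.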